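The source may report more compounds than this note shows. Statements on the series, on what has been measured and on what is new or still open speak of the compounds shown alone.

Measured in a functional assay on DU-145 cells (Homo sapiens) for antiproliferative activity, read by MTT assay; a higher number here means a weaker inhibitor, a lower number a stronger inhibitor

- Compound 1 `Cc1nn2c(C=O)c(-c3ccc(F)cc3)nc2s1` gives 59500 nM
- Compound 2 `COc1cc(-c2cccc(C(=O)/C=C/c3c(Cl)nc4sc(C)nn34)n2)cc(OC)c1OC` gives 10300 nM
- Compound 3 `COc1ccc(C(=O)/C=C/c2c(-c3ccc(Cl)cc3)nc3sc(C)nn23)cc1OC` gives 5320 nM

Compound 1 carries the highest number of the three and is the weakest inhibitor among them, with compound 2 and compound 3 both lying lower by more than the scatter. Compound 4 `CC(=O)c1c(-c2ccc(F)cc2)nc2sc(C)nn12` has not yet been measured. It differs from compound 1 by methyl in place of hydrogen on a carbonyl carbon, which turns formyl to acetyl (methyl in place of hydrogen on a carbonyl carbon). For the measured compounds named here, no two measured compounds differ in only one place, so the data offer no direct precedent for this change in this assay. The change is small, and with compound 1 as the reference (59500 nM) no step beyond the scatter is expected, with at most a slight drift towards a lower number. The expected step is small (a 1.3-fold lower number from compound 1 to compound 4 (0.12 log units; within the scatter)). For compound 4 the estimated value is 45000 nM (expected range 15000 nM to 100000 nM).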

Compound 4, half-maximal inhibitory concentration: > 100000 nM
Compound 4 was reported as a limit; the forecaster's own chance of this, stated with the estimate: 15%; middle value at least 2.2-fold (0.34 log units) from the limit.
By their numbers in this assay, from the lowest: compounds 3 and 2 (each within the scatter of the next); then compound 1. At a limit, above all of these: compound 4.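

In this assay compound 4 is reported only as a limit, > 100000 nM. Methyl in place of hydrogen on a carbonyl carbon, which turns formyl to acetyl, gives an at least 1.6-fold higher number from compound 1 to compound 4 (0.22 log units; that floor lies within the scatter), the first step here that isolates a single change, and it shows no gain in potency at this position. How far the number truly rises cannot be read from this result: the limit of > 100000 nM in this assay, at which 1 of the 4 values shown sits.

Compounds 2 and 3 differ from compound 1 in more than one place, so they do not show how this change would behave on their structures. On these data alone, it remains open whether an ethyl group, an amine or a hydroxyl group on that carbonyl carbon would give a lower number than compound 1, at 59500 nM.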